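The source may hold more compounds than are shown below. What is called first, only, known or untested is meant among the compounds shown, and "the series" means these compounds.

Three compounds built on one shared core have been run through an in vitro ADME assay on microsomes from liver (Homo sapiens) for metabolic stability; on this read-out lower numbers stand for slow clearance and higher numbers for fast clearance. Compound 1 `CN1CC(=O)N/C1=N\C(=O)Nc1ncccc1Cl` carries a chloro group on its aromatic ring, and in this assay compound 1 gives 42 mL.min-1.g-1. Compound 2 `Cc1cccnc1NC(=O)NC1=NC(=O)CN1C` has a methyl group in place of that chloro, and in this assay compound 2 gives 29 mL.min-1.g-1. Compound 3 `CN1CC(=O)N/C1=N\C(=O)Nc1csc(Cl)c1` carries its chloro on a five-membered aromatic ring instead, and in this assay compound 3 gives 55 mL.min-1.g-1. The three numbers lie close together: the gap from compound 1 to compound 3 and the gap from compound 1 to compound 2 each fall within the usual scatter of repeated measurements, so none of the three can be set apart from the others.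

Compound 4 `CN1CC(=O)N/C1=N\C(=O)Nc1ccccn1` has not yet been measured. It differs from compound 1 in one place, (hydrogen in place of chloro on an aromatic carbon), a hydrogen atom standing where the chloro stood. Among the compounds with values here, no measured pair here shows a change of this kind, so the direction of any step is unknown. Since the measured numbers around compound 1 all sit within the scatter of one another, the step from compound 1 to compound 4 is expected to be small as well, an estimated 1.2-fold lower number from compound 1 to compound 4 (0.08 log units; within the scatter). For compound 4 in this assay the expected value is 35 mL.min-1.g-1, with a likely range from 18 mL.min-1.g-1 to 70 mL.min-1.g-1.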

Compound 4, intrinsic clearance in microsomes: 47 mL.min-1.g-1
Compound 4: middle estimate off by 1.3-fold (0.13 log units), on the low side; measured number inside the range.
By their numbers in this assay, from the lowest: compounds 2, 1, 4 and 3 (each within the scatter of the next).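

Removing the chloro group from this aromatic carbon, ortho to a large group and two atoms from the ring nitrogen, and leaving a hydrogen atom there gives a 1.1-fold higher number from compound 1 to compound 4 (0.05 log units; within the scatter) in this assay. Within the data shown here, this is the first pair here that differs in only one place, so it gives a direct reading of a single change: on this read-out, chloro and hydrogen at this position cannot be told apart, and one chlorine atom can go without a step that stands clear of the scatter. No separate measurement is available to explain this result.

As far as these compounds go, this single step compares only chloro and hydrogen, so it remains open whether an amine, a carboxylic acid or a longer chain at the same aromatic carbon would give a step beyond the scatter. It also leaves open whether replacing chloro with hydrogen would give a similarly small step on the five-membered aromatic ring of compound 3, where the chloro group sits in a different setting.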